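The compounds below may be only part of what the source reports. "The series", "measured", "known", "first", "only" and "open" are said of these compounds alone.

Three thiosemicarbazide-type amidrazones have been measured in a functional assay on A-375 cells (Homo sapiens) for cytotoxicity, read by MTT assay, with a stated time of 72 h, tested at 30 uM (a lower number here means less inhibition of growth, a higher number more inhibition of growth at the concentration tested), so far. Compound 1 `Cc1ccnc(/C(N)=N/NC(=S)N2CCCC2)c1` gives 87.9%, compound 2 `N/C(=N\NC(=S)N1CCN(c2ccccn2)CC1)c1ccc(F)cn1` gives 73.2%, and compound 3 `Cc1cccc(/C(N)=N/NC(=S)N2CCCC2)n1` gives 60.8%. Compound 2 thus stands second of the three: its number lies beyond the scatter below that of compound 1 and beyond the scatter above that of compound 3. The new compound 4 `Cc1ccnc(/C(N)=N/NC(=S)N2CCN(c3ccccn3)CC2)c1` arises from compound 2 by 4-methylpyridin-2-yl in place of 5-fluoropyridin-2-yl on a carbon with a double bond to nitrogen. For the measured compounds named here, no directly comparable pair has been measured, so the size of this step is uncertain; since compound 1, which also carries 4-methylpyridin-2-yl, shows 87.9%, a modest upward step is expected, as a number 6.8 percentage points higher from compound 2 to compound 4 (within the scatter). Compound 4 is therefore estimated to give 80%, within 65% to 92%.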

Compound 4, percent growth inhibition at one concentration: 79.4%
Compound 4: middle estimate off by 0.6 percentage points, on the high side; measured number inside the range.
By their numbers in this assay, from the lowest: compound 3; then compounds 2, 4 and 1 (each within the scatter of the next, the first and the last beyond it).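

For the compounds shown here, on the shared core, this is the first pair differing in one place, and it reads directly at the carbon with a double bond to nitrogen: in this assay, 4-methylpyridin-2-yl in place of 5-fluoropyridin-2-yl gives a number 6.2 percentage points higher from compound 2 to compound 4 (within the scatter), so this assay does not separate these two groups here. No measurement on hand accounts for this result.

Going by these compounds, it remains open whether a pyridine ring carrying an amine or a carboxylic acid would fit this pattern at this place. On these data alone, it is also open whether the same exchange would read alike on the core of compound 1.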